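A five-membered ring swap, tried twice in cell inhibition

This account rests on a few compounds, and the source may have more. Where it says the series, first, only, none or still open, it means among the compounds named here.

Measured so far in a functional assay on LoVo cells (Homo sapiens) for inhibition, read by MTT assay, with a stated time of 72 h; on this read-out lower numbers stand for stronger inhibition and higher numbers for weaker inhibition:
compound 1 `Cc1noc(C)c1-c1cnc(N)c(Oc2ccc(C(=O)Nc3cccc(Cl)c3)cc2)n1` gives 1640 nM.
compound 2 `Cn1cc(-c2cnc(N)c(Oc3ccc(C(=O)Nc4cccc(Cl)c4)cc3)n2)cn1` gives 24500 nM.
compound 3 `Cc1noc(C)c1-c1cnc(N)c(NCc2ccc(C(=O)Nc3ccc(Cl)cc3)cc2)n1` gives only a limit of the assay, > 100000 nM.

Compound 2 differs from compound 1 by 1-methyl-1H-pyrazol-4-yl in place of 3,5-dimethyl-1,2-oxazol-4-yl on an aromatic carbon, and this single change brought a 15-fold higher number from compound 1 to compound 2 (1.17 log units; beyond the scatter), a clear weakening. How the core of compound 3 differs from that of compound 1 is not broken down here. In this assay compound 3 reaches no number at all but only a limit, namely (the limit of > 100000 nM in this assay, at which 1 of the 3 values shown sits).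

Compound 4 `Cn1cc(-c2cnc(N)c(NCc3ccc(C(=O)Nc4ccc(Cl)cc4)cc3)n2)cn1` has not yet been measured. It differs from compound 3 by 1-methyl-1H-pyrazol-4-yl in place of 3,5-dimethyl-1,2-oxazol-4-yl on an aromatic carbon, which is the same change, at the same place, as that between compound 1 and compound 2. Since that earlier step was a weakening, the step from compound 3 to compound 4 is expected to be a step that the limit leaves unreadable from compound 3 to compound 4, and compound 4 is therefore expected to stay at the limit of this assay. The estimated value for compound 4 in this assay is 300000 nM, expected between 100000 nM and 1500000 nM, most likely reported only as a limit.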

Compound 4, half-maximal inhibitory concentration: 43600 nM
Estimate against measurement, compound 4: 6.9-fold (0.84 log units) above; the measured number lies below the stated range.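

In this assay, putting 1-methyl-1H-pyrazol-4-yl in place of 3,5-dimethyl-1,2-oxazol-4-yl gave an at least 2.2-fold lower number from compound 3 to compound 4 (0.36 log units; beyond the scatter), so this change did not carry over from one core to the other with the same direction. Set side by side, the two steps part clearly: the same change on two cores in this assay, a 15-fold higher number (1.17 log units; beyond the scatter) from compound 1 to compound 2 and an at least 2.2-fold lower number (0.36 log units; beyond the scatter) from compound 3 to compound 4, at least 34-fold (1.53 log units) apart, beyond the scatter of two such steps

Compound 3 gives only a limit of the assay, > 100000 nM, so the step to compound 4 has a minimum size but no full size, and the data do not show which of the differences between the two cores goes with the change of direction.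

Only two cores and two five-membered rings are shown, which leaves open how a pyridine or a morpholine at that place would fare on either core. Also open, from the compounds shown here alone, is whether the same change on a third core would follow the step between compound 1 and compound 2 or the step between compound 3 and compound 4.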